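A few compounds are considered here, and "the series" means these few. Any claim that something is new, unique, unknown or untested is made for them only; others in the source may bear on it.

Working notes on the series, read in a functional assay on HL-60 cells (Homo sapiens) for inhibition, read by MTT assay, with a stated time of 72 h; on this read-out higher numbers stand for weaker inhibition and lower numbers for stronger inhibition. Compound 1 `Cc1nc(-c2ccc(F)cc2)c(C(=O)N2CCN(c3cc(Cl)cc(Cl)c3)CC2)o1` gives 52.1 nM and compound 2 `COc1cc(OC)cc(N2CCN(C(=O)c3oc(C)nc3-c3ccccc3F)CC2)c1` gives 10.3 nM. Compound 2 therefore holds the lower of the two numbers, and the gap lies beyond the usual scatter. These two compounds differ in more than one place, so no single change can be read from them. Compound 3 `COc1cc(OC)cc(N2CCN(C(=O)c3oc(C)nc3-c3ccc(F)cc3)CC2)c1` is not yet measured. It differs from compound 2 as follows: 4-fluorophenyl in place of 2-fluorophenyl on an aromatic carbon. For the measured compounds named here, no measured pair isolates this change. Going by the values given here, compound 1, the only measured compound with 4-fluorophenyl, gives 52.1 nM, and on that ground a modest rise in the number is expected in this assay. The estimated change is a 2.1-fold higher number from compound 2 to compound 3 (0.33 log units; beyond the scatter). For compound 3 the estimated value is 22 nM, within a range of 6 nM to 80 nM.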

Compound 3, half-maximal inhibitory concentration: 38.5 nM
For compound 3 the middle estimate is 1.8-fold (0.24 log units) below the measured one; the range from low to high includes it.
By their numbers in this assay, from the lowest: compound 2; then compounds 3 and 1 (each within the scatter of the next).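

With the 3,5-dimethoxyphenyl group held constant, 4-fluorophenyl in place of 2-fluorophenyl on the aromatic carbon of the five-membered ring gives a 3.7-fold higher number from compound 2 to compound 3 (0.57 log units; beyond the scatter) in this assay and so shows that the place of the fluorine on this phenyl alone shifts the read-out beyond the scatter. With 4-fluorophenyl held constant, 3,5-dimethoxyphenyl in place of 3,5-dichlorophenyl on the amine nitrogen in a ring gives a 1.4-fold lower number from compound 1 to compound 3 (0.13 log units; within the scatter) and so separates the two groups by no more than the scatter in this setting. Nothing on hand explains either step.

As far as these compounds go, whether the fluorine change reads the same with 3,5-dichlorophenyl on the ring nitrogen remains open. Also open, from the compounds shown here alone, is how an unsubstituted phenyl, 3-fluorophenyl or 2-chlorophenyl would read at this place on the five-membered ring.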